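Swapping Thiophene for Chlorophenyl on a Triazole Amide

The source may report more compounds than this note shows. Statements on the series, on what has been measured and on what is new or still open speak of the compounds shown alone.

Compound 1 `COc1ccc(-c2cn(CC(=O)Nc3nc4ccccc4s3)nn2)cc1`: 1330 nM
Compound 2 `CCOC(=O)c1sc(NC(=O)Cn2cc(-c3cccs3)nn2)nc1C`: 20 nM
Compound 3 `O=C(Cn1cc(-c2ccc(F)cc2)nn1)Nc1nc2ccccc2s1`: a limit, > 30000 nM

All three were tested in a functional assay on BMDM cells (Mus musculus, strain C57BL/6) for inhibition, with a stated time of 2 days; on this read-out higher numbers stand for weaker inhibition and lower numbers for stronger inhibition. Compound 2 gives the lower of the two numbers, compound 1 a clearly higher one. Compound 3 gives only a limit, not a number. Compound 4 `CCOC(=O)c1sc(NC(=O)Cn2cc(-c3ccc(Cl)cc3)nn2)nc1C` differs from compound 2 by 4-chlorophenyl in place of thiophen-2-yl on an aromatic carbon. For the measured compounds named here, no measured step covers this exact change. Going by the values given here, the one measured step, an at least 22-fold higher number from compound 1 to compound 3 (1.35 log units; beyond the scatter), shows that altering the group on the triazole can weaken inhibition strongly, so for compound 4 a moderate weakening is expected, a 7.5-fold higher number from compound 2 to compound 4 (0.88 log units; beyond the scatter). Compound 4 is therefore estimated at 150 nM, with a likely range from 25 nM to 1500 nM.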

Compound 4, half-maximal inhibitory concentration: 180 nM
For compound 4 the middle estimate is 1.2-fold (0.08 log units) below the measured one; the measured number falls inside the stated range.
By their numbers in this assay, from the lowest: compound 2; then compound 4; then compound 1. At a limit, above all of these: compound 3.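

On the core of compound 2, replacing the whole ring at this position gives a 9.0-fold higher number from compound 2 to compound 4 (0.95 log units; beyond the scatter). Inhibition weakens, but compound 4 keeps a measurable value, so thiophen-2-yl is the better of these two groups here, and a six-membered ring is not ruled out. The earlier step changed only a group on the aromatic ring and on a different core, so it did not show this.

On these data alone, compound 3 gives only a limit, so the full size of that earlier step stays open: the limit of > 30000 nM in this assay, at which 1 of the 4 values shown sits. Whether a saturated ring such as cyclohexyl or a simple amine would work at this position also stays open.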